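The source may hold more compounds than are shown below. What is called first, only, known or untested is meant among the compounds shown, and "the series" means these compounds.

Of the compounds shown here, two built on the same core have been measured in a functional assay on the whole organism for inhibition, with Mus musculus as the target, at a dose of 30 mg/kg by the oral route; a lower number here means less inhibition, a higher number more inhibition at the dose given (going by the name of the read-out). Compound 1, with structure `O=C(NCCCOc1ccc2nc(O)ccc2c1)N(C1CC1)[C@@H]1CCC[C@H]1O`, carries a 2-hydroxycyclopentyl group on an amide-type nitrogen, and in this assay compound 1 gives 67%. Compound 2, with structure `O=C(NCCCOc1ccc2nc(O)ccc2c1)N(C1CC1)[C@@H]1CCC[C@@H](O)C1`, carries a 3-hydroxycyclohexyl group at that same nitrogen instead, and in this assay compound 2 gives 20%. Among the measured compounds shown here, the one step measured so far is a number 47 percentage points lower from compound 1 to compound 2 (beyond the scatter), so on the two numbers at hand compound 2 stands lowest, with compound 1 the only and higher neighbour.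

Compound 3, with structure `O=C(NCCCOc1ccc2nc(O)ccc2c1)N(C1CC1)[C@H]1CC[C@H](O)CC1`, has not yet been measured. The change from compound 2 is 4-hydroxycyclohexyl in place of 3-hydroxycyclohexyl on an amide-type nitrogen. For the measured compounds named here, the only measured step touches this same nitrogen, but it swaps one ring for another rather than moving a hydroxyl around one ring, so it bears on the present change only loosely. With no closer guide, the step of a number 5 percentage points higher from compound 2 to compound 3 (within the scatter) is expected to stay within the scatter. Compound 3 is therefore estimated at 25% in this assay, in a range from 5% to 55%.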

Compound 3, a percentage reported as inhibition, in the whole organism at one dose (the size of the read-out at that dose, not a potency): 0%
For compound 3 the middle estimate is 25 percentage points above the measured one, and the stated range ends above it.
By their numbers in this assay, from the lowest: compound 3; then compound 2; then compound 1.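

Among the compounds shown here, until now, the only measured change at this amide-type nitrogen replaced one ring with another, so ring size and hydroxyl placement could not be told apart. Here the ring stays a six-membered carbon ring and the atoms stay the same, yet in this assay replacing 3-hydroxycyclohexyl with 4-hydroxycyclohexyl gives a number 20 percentage points lower from compound 2 to compound 3 (beyond the scatter) as the outcome, which shows that hydroxyl placement alone can shift this read-out beyond the scatter. The 2-hydroxycyclopentyl group remains the best of the three at this nitrogen, with a number 67 percentage points lower from compound 1 to compound 3 (beyond the scatter) as the widest gap so far, and no supporting data explain why these groups rank in this order.

Compound 1 differs from the other two in both ring size and hydroxyl placement, so 2-hydroxycyclohexyl and 3-hydroxycyclopentyl would be needed to separate those two features. Also open, on these data alone, are the role of the hydroxyl itself, which plain cyclohexyl or cyclopentyl would test, the effect of an amine or a carboxylic acid in its place, and the effect of the other stereoisomers of these rings.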